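The source may hold more compounds than are shown below. What is called first, only, known or untested is meant among the compounds shown, and "the series" means these compounds.

Of the compounds shown here, three built on one shared core have been tested in a functional assay on A549 cells (Homo sapiens) for cytotoxicity, read by MTT assay, with a stated time of 72 h; on this read-out higher numbers stand for weaker inhibition and lower numbers for stronger inhibition. Compound 2 `CNC(=O)c1cc(Oc2ccc(NC(=O)c3nccc(-c4ccc(C)cc4)n3)cc2)ccn1` is the only one of them with a number: in this assay compound 2 gives 28400 nM. Compound 3 `CNC(=O)c1cc(Oc2ccc(NC(=O)c3cc(-c4ccc(F)cc4)ncn3)cc2)ccn1` reaches only a limit of the assay, and in this assay compound 3 gives > 100000 nM. Compound 1 `CNC(=O)c1cc(Oc2ccc(NC(=O)c3cc(-c4ccc(F)cc4)ncn3)cc2F)ccn1` likewise reaches only a limit, and in this assay compound 1 gives > 100000 nM. The change from compound 3 to compound 1 is fluoro in place of hydrogen on an aromatic carbon, and its size in this assay is a step that the two limits leave unreadable from compound 3 to compound 1, which stays unreadable because of the limit of > 100000 nM in this assay, at which 2 of the 3 values shown sit. How the core of compound 2 differs from the core of compound 3 is not broken down here.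

Compound 4 `CNC(=O)c1cc(Oc2ccc(NC(=O)c3nccc(-c4ccc(C)cc4)n3)cc2F)ccn1` has not yet been measured. From compound 2 to compound 4 the change is fluoro in place of hydrogen on an aromatic carbon, the same change as from compound 3 to compound 1, made at the same place. That earlier step gives no readable size, so the expectation rests on compound 2 alone and its value of 28400 nM in this assay. The step from compound 2 to compound 4 is expected to be a 1.4-fold higher number from compound 2 to compound 4 (0.15 log units; within the scatter), set beside the unreadable earlier one. Compound 4 is therefore expected to give about 40000 nM in this assay, between 14000 nM and 100000 nM.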

Compound 4, half-maximal inhibitory concentration: 33200 nM
Compound 4: the middle estimate sits 1.2-fold (0.08 log units) above what was measured; measured number inside the range.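

In this assay, fluoro in place of hydrogen on an aromatic carbon, ortho to a (2-(methylcarbamoyl)pyridin-4-yl)oxy group, gives a 1.2-fold higher number from compound 2 to compound 4 (0.07 log units; within the scatter), so on this core the read-out does not separate the two compounds. The same change on the other core, taking compound 3 to compound 1, cannot be read, because both compounds give a limit of the assay and not a number: the limit of > 100000 nM in this assay, at which 2 of the 4 values shown sit. Among these compounds, the result therefore shows that the change makes no measurable difference on one core, but it does not show that the change behaves alike on both cores, since only one of the two steps has a size.

The compounds shown leave open whether a chlorine atom or a methoxy group on the same aromatic carbon would behave as fluoro does. They also leave open what an amine or a carboxylic acid in place of the methyl group of compound 2 would do to the number.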